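Pyrazolyl for hydroxyethyl on the amide nitrogen

A few compounds are considered here, and "the series" means these few. Any claim that something is new, unique, unknown or untested is made for them only; others in the source may bear on it.

Measured compounds:
compound 1 `Cc1ccc(OCC(=O)N(Cc2cccs2)C2COC2)cc1` 23000 nM
compound 2 `Cc1ccc(OCC(=O)N(Cc2cccs2)C2CCCCC2)cc1` 40000 nM
compound 3 `Cc1ccc(OCC(=O)N(CCO)Cc2cccs2)cc1` 900 nM

In an assay on HEK293 cells for agonist activity at transient receptor potential cation channel subfamily M member 8 (Homo sapiens), read by fluorescence and calcium flux, with a stated time of 15 min (a higher number here means that more compound is needed for the effect, a lower number that less compound is needed), compound 3 gives the lowest number of the three. The step of a 26-fold lower number from compound 1 to compound 3 (1.41 log units; beyond the scatter) and the step of a 44-fold lower number from compound 2 to compound 3 (1.65 log units; beyond the scatter) both run in its favour, while the step of a 1.7-fold higher number from compound 1 to compound 2 (0.24 log units; within the scatter) lies within the scatter, so the two ring-bearing compounds 1 and 2 cannot be ordered against each other.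

Compound 4 `Cc1ccc(OCC(=O)N(Cc2cccs2)c2ccn[nH]2)cc1` has not yet been measured in this assay. It differs from compound 3 in one place: 1H-pyrazol-5-yl in place of 2-hydroxyethyl on an amide-type nitrogen.

Both large steps known here bear on this change from the same side: whenever the amide-type nitrogen carried a ring, oxetan-3-yl or cyclohexyl, the number was far higher than with 2-hydroxyethyl. Going by the values given here, compound 4 again carries a ring on that nitrogen, though an aromatic one with a hydrogen-bond donor and acceptor, which none of the measured compounds has. The expectation is therefore a step of a 5.6-fold higher number from compound 3 to compound 4 (0.74 log units; beyond the scatter) toward a higher number, most likely beyond the scatter but smaller than the steps seen with the saturated rings. Compound 4 is estimated at 5000 nM, with a range from 1000 nM to 30000 nM.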

Compound 4, half-maximal effective concentration: 0.2 nM
The estimate for compound 4 lay 25000-fold (4.40 log units) above the measured number, and the stated range ends above it.
By their numbers in this assay, from the lowest: compound 4; then compound 3; then compounds 1 and 2 (each within the scatter of the next).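

In this assay, 1H-pyrazol-5-yl in place of 2-hydroxyethyl on the amide-type nitrogen gives a 4500-fold lower number from compound 3 to compound 4 (3.65 log units; beyond the scatter), so a ring at this position does not by itself raise the number, as compounds 1 and 2 had suggested. The kind of ring matters: replacing the saturated rings gives a 120000-fold lower number from compound 1 to compound 4 (5.06 log units; beyond the scatter) for oxetan-3-yl and a 200000-fold lower number from compound 2 to compound 4 (5.30 log units; beyond the scatter) for cyclohexyl. Since 2-hydroxyethyl and 1H-pyrazol-5-yl have the same donor and acceptor counts, those counts alone do not separate compound 3 from compound 4.

No evidence here accounts for the size of this step. The compounds shown leave open whether the ring nitrogens are needed, which a phenyl ring on the amide-type nitrogen would test, and whether the ring hydrogen on nitrogen is needed, which a 1-methylpyrazolyl group there would test.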